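Lengthening the Ethyl Arm on a Tertiary Amine

The source may report more compounds than this note shows. Statements on the series, on what has been measured and on what is new or still open speak of the compounds shown alone.

Compound 1 `CCCCNc1cc(C)nc2c(-c3ccc(Cl)cc3Cl)nn(C)c12`: 170 nM
Compound 2 `CCCN(C)c1cc(C)nc2c(-c3ccc(Cl)cc3Cl)nn(C)c12`: 24 nM
Compound 3 `CCN(CC1CC1)c1cc(C)nc2c(-c3ccc(Cl)cc3Cl)nn(C)c12`: 4.4 nM

Of the compounds shown here, three sharing one core have been tested in an assay on HEK293 cells for displacement of a labelled ligand from corticotropin-releasing factor receptor 1 (Homo sapiens); a higher number here means a weaker inhibitor, a lower number a stronger inhibitor. Compound 3 stands at the lowest number of the three: in this assay compound 3 gives 4.4 nM, and its nearest neighbour is compound 2, which gives 24 nM, with a 5.5-fold lower number from compound 2 to compound 3 (0.74 log units; beyond the scatter). Furthest away is compound 1, which gives 170 nM, so that a 39-fold lower number from compound 1 to compound 3 (1.59 log units; beyond the scatter). Between the two weaker compounds, a 7.1-fold lower number from compound 1 to compound 2 (0.85 log units; beyond the scatter).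

Compound 4 `CCCN(CC1CC1)c1cc(C)nc2c(-c3ccc(Cl)cc3Cl)nn(C)c12` differs from compound 3 by methyl in place of hydrogen on a saturated chain carbon, two bonds along the chain from a nitrogen on an aromatic ring. Among the measured compounds shown here, none of the measured steps is a simple lengthening of a chain on the tertiary amine; each of them changes two arms at once or turns a secondary amine into a tertiary one. Those steps were modest to large, but they do not speak to a single added carbon on the ethyl arm. The expectation is therefore a step for a 1.0-fold higher number from compound 3 to compound 4 (0.01 log units; within the scatter) that stays within the scatter, in either direction. Compound 4 is estimated to give 4.5 nM in this assay, with a range from 1.5 nM to 13 nM.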

Compound 4, inhibition constant: 1.7 nM
For compound 4 the middle estimate is 2.6-fold (0.42 log units) above the measured one; low and high end bracket the measured number.
By their numbers in this assay, from the lowest: compound 4; then compound 3; then compound 2; then compound 1.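

In this assay, among the compounds shown here, the change from ethyl to propyl on the tertiary amine, with the cyclopropylmethyl arm held fixed, is the first step in which only one chain grows by a single carbon, and it lies beyond the scatter (a 2.6-fold lower number from compound 3 to compound 4 (0.41 log units; beyond the scatter)), so this arm is sensitive to methyl in place of hydrogen on a saturated chain carbon, two bonds along the chain from a nitrogen on an aromatic ring. With the propyl arm now held fixed, cyclopropyl in place of hydrogen on the second arm also gives a large step (a 14-fold lower number from compound 2 to compound 4 (1.15 log units; beyond the scatter)), and compound 4 ends at the low end of the set, well clear of the secondary amine (a 100-fold lower number from compound 1 to compound 4 (2.00 log units; beyond the scatter)). No evidence is available that bears on why the longer arm gives the lower number.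

The compounds shown leave open whether the trend continues beyond propyl, which a butyl arm or a branched isopropyl arm in the same place would test. They also leave open whether the same lengthening would count for as much with a methyl arm in place of cyclopropylmethyl.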